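The source may hold more compounds than are shown below. What is called first, only, known or untested is meant among the compounds shown, and "the series" means these compounds.

Of the compounds shown here, two have so far been measured in a functional assay on PBMC cells (Homo sapiens) for inhibition, read by ELISA, with a stated time of 18 h; on this read-out lower numbers stand for stronger inhibition and higher numbers for weaker inhibition. Compound 1 `CC1(C)CC(=O)C(C(=S)SCc2ccccc2)=C(Nc2ccc(Cl)cc2Cl)C1` reaches only a limit of this assay, not a number: > 20 ug/mL. Compound 2 `CC(=O)OC[C@H]1O[C@@H](SC(=S)C2=C(Nc3ccc(Cl)cc3Cl)CC(C)(C)CC2=O)[C@H](OC(C)=O)[C@@H](OC(C)=O)[C@@H]1OC(C)=O` likewise gives only a limit in this assay, > 20 ug/mL. Compound 2 thus stands at the edge of what this assay can report, and both measured values sit at the limit of > 20 ug/mL in this assay, at which 2 of the 2 values shown sit. Compound 3 `CC(=O)OC[C@H]1O[C@@H](SC(=S)C2=C(Nc3ccc(Cl)cc3Cl)CC(C)(C)CC2=O)[C@H](OC(C)=O)[C@@H](OC(C)=O)[C@H]1OC(C)=O` has not been measured. Its difference from compound 2 is small: the two compounds have the same atoms and bonds and differ only in configuration as drawn: 1 of 5 stereo elements differ; a stereocentre at a saturated ring carbon is drawn R in compound 2 and S in compound 3. Every atom and bond is kept, and the two compounds already measured both ended at a limit, so the expected step that the limit leaves unreadable from compound 2 to compound 3 is none beyond the usual scatter. Compound 3 is estimated to give about 30 ug/mL in this assay, within a range from 12 ug/mL to 80 ug/mL, and the result is expected most likely to be reported again only as a limit.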

Compound 3, half-maximal inhibitory concentration: 2.1 ug/mL
Beside the measured number, compound 3's estimate is 14-fold (1.15 log units) above it, and the stated range ends above it.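

In this assay, changing a single stereocentre at a saturated ring carbon from R to S gives an at least 9.5-fold lower number from compound 2 to compound 3 (0.97 log units; beyond the scatter). Within the data shown here, until this result, this assay had reported nothing but a limit, not a number: the limit of > 20 ug/mL in this assay, at which 2 of the 3 values shown sit. The change in the read-out can be tied to the spatial arrangement at this one carbon alone, because no atom or bond is gained or lost: the fact that compounds 2 and 3 differ only in the configuration as drawn.

The compounds shown leave open whether the other stereo elements matter as much as this one, since each of them stays the same between these two compounds. They also leave open whether the effect of this configuration survives when a free hydroxyl group replaces the acetate esters, or when an amine stands on the ring in their place.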